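Hydrazone thiazole series: fluoro on the phenyl ring

This account rests on a few compounds, and the source may have more. Where it says the series, first, only, none or still open, it means among the compounds named here.

Measured compounds and their read-outs in a functional assay, read by spectrophotometry, with a stated time of 15 min, tested at 60 ug/mL; a lower number here means a weaker effect, a higher number a stronger effect of the compound at the concentration tested:
- compound 1, `COC(=O)c1cc(-c2csc(N/N=C/c3ccc(Cl)cc3Cl)n2)ccc1OCc1ccccc1`: 41.9%
- compound 2, `Cc1ccc(-c2csc(N/N=C/c3cccs3)n2)cc1`: 97.6%
- compound 3, `Clc1ccc(/C=N/Nc2nc(-c3ccccc3)cs2)c(Cl)c1`: 92.8%

Compound 3 stands second highest of the three numbers in this assay. Its nearest neighbour is compound 2, whose number is higher by an amount that lies within the usual scatter, so no order between compound 2 and compound 3 can be read from these two values. Compound 1 is furthest away, with a number lower than that of compound 3 by an amount beyond the scatter.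

Compound 4, `Fc1ccc(-c2csc(N/N=C/c3ccc(Cl)cc3Cl)n2)cc1`, has not yet been measured in this assay. It differs from compound 3 in one place: fluoro in place of hydrogen on an aromatic carbon. Among the measured compounds shown here, no pair of measured compounds shows this change, so no measured step is available to lean on; the expectation rests on the value of compound 3 alone.

Compound 4 is expected to give 90%, with a range from 75% to 99%. The estimated step of a number 2.8 percentage points lower from compound 3 to compound 4 (within the scatter) is expected to be small, in either direction, and not beyond the scatter, because compound 3 already reads 92.8% and a single fluoro is a small change to the structure.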

Compound 4, a percentage reported as inhibition, at one concentration (the size of the read-out at that concentration, not a potency): 94.6%
Estimate against measurement, compound 4: 4.6 percentage points below; measured number inside the range.
By their numbers in this assay, from the lowest: compound 1; then compounds 3, 4 and 2 (each within the scatter of the next).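

In this assay, among the compounds shown here, the change from phenyl to 4-fluorophenyl gives the first step between measured compounds in this set, a number 1.8 percentage points higher from compound 3 to compound 4 (within the scatter), so no order can be read between the two. On this aromatic carbon, para to a large group, fluoro in place of hydrogen therefore costs nothing measurable at the concentration tested: compound 4 gives 94.6%, which keeps the read-out of this dichlorophenyl hydrazone at the high level already seen for compound 3, and this single step is all that is known about the position. No available measurement bears on why the read-out is unmoved by this change.

The compounds shown leave open whether the position accepts anything other than hydrogen or fluoro, for example an amine, a carboxylic acid or a longer alkyl chain, and whether fluoro behaves the same way when the rest of the molecule differs. A read-out taken at one concentration, with both compounds high on the percentage scale, also leaves open any difference in potency between them.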